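A new aryl group on the shared core

The compounds below may be only part of what the source reports. "The series", "measured", "known", "first", "only" and "open" are said of these compounds alone.

Within the data shown here, in a functional assay on HeLa cells (Homo sapiens) for cytotoxicity, read by MTT assay, with a stated time of 72 h (a lower number here means a stronger inhibitor, a higher number a weaker inhibitor), compound 1 (`Cn1ccc2c(Oc3ccc(NC(=O)c4cc5cccnc5n(-c5ccc(Br)cc5)c4=O)cc3)ncnc21`) gives 43800 nM and compound 2 (`COc1ccc(-n2c(=O)c(C(=O)Nc3ccc(Oc4ncnc5c4ccn5C)cc3)cc3cccnc32)cc1`) gives 65800 nM, so compound 2 stands within the scatter of its only neighbour. Compound 3 (`Cn1ccc2c(Oc3ccc(NC(=O)c4cc5cccnc5n(-c5ccc(C(F)(F)F)cc5Cl)c4=O)cc3)ncnc21`) carries 2-chloro-4-(trifluoromethyl)phenyl in place of 4-methoxyphenyl on an aromatic nitrogen. Among the measured compounds shown here, the one measured change on this aryl group, methoxy in place of bromo, gave a 1.5-fold higher number from compound 1 to compound 2 (0.18 log units; within the scatter) and stayed within the scatter. On that single step, no shift beyond the scatter is expected in this assay for the new group. The expected change is a 1.5-fold lower number from compound 2 to compound 3 (0.17 log units; within the scatter) and nothing larger. For compound 3 the estimated value is 45000 nM with an expected range from 15000 nM to 120000 nM (not yet measured).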

Compound 3, half-maximal inhibitory concentration: 174000 nM
Compound 3: middle estimate off by 3.9-fold (0.59 log units), on the low side; measured number outside the range, above it.
By their numbers in this assay, from the lowest: compounds 1 and 2 (each within the scatter of the next); then compound 3.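

This aryl group on the aromatic nitrogen can shift the number in this assay beyond the scatter, which the swap of bromo for methoxy did not show: 2-chloro-4-(trifluoromethyl)phenyl gives a 2.6-fold higher number from compound 2 to compound 3 (0.42 log units; beyond the scatter) and a 4.0-fold higher number from compound 1 to compound 3 (0.60 log units; beyond the scatter) as well. Both steps point to a weaker inhibitor. Nothing available explains this loss.

The new group brings chloro and trifluoromethyl together, so these compounds cannot separate their shares of the step. Going by these compounds, how an amine or a carboxylic acid on this aryl ring would behave stays open.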